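The compounds below may be only part of what the source reports. "The series", "measured", "known", "first", "only" and "open" are said of these compounds alone.

Working notes on the series. In an ADME assay on HEK293 cells (Homo sapiens) for cytotoxicity, with a stated time of 72 h (on this read-out lower numbers stand for an effect already at smaller amounts and higher numbers for an effect only at larger amounts of compound), compound 1 (`Cc1cc(NC(=O)Nc2ccc(C(C)(C)C)cc2)c2ccccc2n1`) reads > 25000 nM as a limit of the assay and not a number. Compound 2 (`Cc1cc(NC(=O)Nc2ccc(C)c(Cl)c2)c2ccccc2n1`) reads > 25000 nM as a limit in the same way. Compound 3 (`Cc1cc(NC(=O)Nc2ccccc2N)c2ccccc2n1`) reads > 25000 nM as a limit too, so it stands without a number of its own. The measured set comes down to the limit of > 25000 nM in this assay, at which 3 of the 3 values shown sit, and offers no number to scale from.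

The next compound is compound 4 (`Cc1ccc(NC(=O)Nc2cc(C)nc3ccccc23)cc1`). Its change from compound 3 is 4-methylphenyl in place of 2-aminophenyl on an amide-type nitrogen and in words it puts 4-methylphenyl in place of 2-aminophenyl on an amide-type nitrogen. Going by the values given here, no step between measured compounds is available to size this change. Compounds 1 and 2 carry other groups on that nitrogen, and neither gives a number in this assay. No step beyond the scatter is expected in either direction, and this expectation rests on the reading of > 25000 nM for compound 3 as a limit. The expected change is a number no higher from compound 3 to compound 4 (the limit leaves the size open) on this estimate. Compound 4 is estimated at 25000 nM within a range of 12000 nM to 50000 nM and a reading that is only a limit is the likeliest outcome.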

Compound 4, half-maximal effective concentration: > 25000 nM
Compound 4 ended at the assay's limit; the forecaster's own chance of this, stated with the estimate: 85%; the middle value lies on the limit itself.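

In this assay compound 4 reads > 25000 nM, a limit and not a number. No step to compound 4 from compounds 1, 2 or 3 can be read, because all four compounds share one limit: the limit of > 25000 nM in this assay, at which 4 of the 4 values shown sit.

The compounds shown leave open whether any member of the series has a measurable half-maximal effective concentration in this assay, and how far these group changes would move it.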